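The compounds below may be only part of what the source reports. "The series", "measured", "known", "first", "only" and "open" are said of these compounds alone.

Measured so far in an assay on isolated protein for inhibition of 2-Hydroxyacid oxidase 1 (Homo sapiens), with stated times of 30 min and 15 min; a lower number here means a stronger inhibitor, a higher number a weaker inhibitor:
- compound 1, `CC(C)c1coc(-c2cccc(CNc3ccc4[nH]nc(C(=O)O)c4c3)c2O)n1`, gives 87 nM
- compound 2, `Cc1nc(-c2cccc(CN(C)c3ccc4[nH]nc(C(=O)O)c4c3)c2)sc1C`, gives 290 nM
- compound 3, `CN(C)c1noc(-c2cccc(CNc3ccc4[nH]nc(C(=O)O)c4c3)c2Cl)n1`, gives 180 nM

Compound 1 holds the lowest number of the three. Compound 3 sits nearest, and the gap from compound 1 to compound 3 is beyond the usual scatter; compound 2 sits furthest, also beyond the scatter. For the measured compounds named here, all three carry a five-membered aromatic ring on the benzylic ring that links to the shared core, and no measured pair differs in one place only, so no single step in this assay can be read off directly.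

Compound 4, `Cc1cccc(CNc2ccc3[nH]nc(C(=O)O)c3c2)c1O`, is not yet measured. Relative to compound 1 the change is methyl in place of 4-isopropyl-1,3-oxazol-2-yl on an aromatic carbon. Going by the values given here, nothing among the measured compounds shows what removing the five-membered aromatic ring at that position does, so the expectation rests on the observation that every measured compound keeps such a ring there. The step from compound 1 to compound 4 is expected to be a clear rise in this assay, an 11-fold higher number from compound 1 to compound 4 (1.06 log units; beyond the scatter), well beyond the scatter. Compound 4 is therefore estimated at 1000 nM, with a range from 300 nM to 4000 nM.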

Compound 4, half-maximal inhibitory concentration: 17000 nM
Compound 4: middle estimate off by 17-fold (1.23 log units), on the low side, and the stated range ends below it.
By their numbers in this assay, from the lowest: compound 1; then compounds 3 and 2 (each within the scatter of the next); then compound 4.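

In this assay, for the compounds shown here, methyl in place of 4-isopropyl-1,3-oxazol-2-yl on this aromatic carbon, ortho to a hydroxy group, gives a 200-fold higher number from compound 1 to compound 4 (2.29 log units; beyond the scatter), a large step and the first direct reading of a change at this position. The shared core and the hydroxy group are present in both compounds, so these parts alone do not keep the number near that of compound 1, and the group at this carbon has a large bearing on the result in this series. No measurement shown addresses the reason for a step of this size.

This single step removes the ring, its two hetero atoms and the isopropyl group together, so it leaves open which of these matters: an unsubstituted oxazol-2-yl, a phenyl group or an open butyl chain at this carbon would separate them. Going by these compounds alone, compounds 2 and 3 carry other five-membered aromatic rings but differ from compound 1 and compound 4 in more than one place, so no steps involving them can be read, and the effect of ring identity at this position also remains open.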